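The source may report more compounds than this note shows. Statements on the series, on what has been measured and on what is new or still open speak of the compounds shown alone.

In a functional assay on HepG2 cells (Homo sapiens) for cytotoxicity, read by MTT assay, with a stated time of 48 h (a higher number here means a weaker inhibitor, a lower number a stronger inhibitor), compound 1 (`O=C1/C(=C\c2ccc(O)cc2)S/C(=N/c2ccccc2)N1Cc1ccncc1`) reads 11800 nM and compound 2 (`CN(C)c1ccc(/C=C2/S/C(=N/c3ccccc3)N(Cc3ccncc3)C2=O)cc1`) reads 52600 nM while compound 3 (`CCOc1cc(/C=C2/S/C(=N/c3ccccc3)N(Cc3ccncc3)C2=O)ccc1O`) reads 20400 nM on the same scale. Compound 3 belongs to the lower pair of these three numbers: the pair lies within the scatter of each other (a 1.7-fold higher number from compound 1 to compound 3 (0.24 log units; within the scatter)), and the gap to the remaining number is modest but beyond the scatter (a 2.6-fold lower number from compound 2 to compound 3 (0.41 log units; beyond the scatter)).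

Compound 4 (`COc1ccc(OC)c(/C=C2/S/C(=N/c3ccccc3)N(Cc3ccncc3)C2=O)c1`) has 2,5-dimethoxyphenyl in place of 3-ethoxy-4-hydroxyphenyl on a double-bonded chain carbon bound to a double-bonded ring carbon. Going by the values given here, no measured step makes this exact exchange. The closest evidence comes from two changes on the same aromatic group. Dimethylamino in place of hydroxy gave a modest rise in the number (a 4.5-fold higher number from compound 1 to compound 2 (0.65 log units; beyond the scatter)), and ethoxy in place of hydrogen stayed within the scatter (a 1.7-fold higher number from compound 1 to compound 3 (0.24 log units; within the scatter)). Compound 4 also has no hydroxy, so a small rise is expected, and it may not exceed the scatter. The expected step is a 1.4-fold higher number from compound 3 to compound 4 (0.14 log units; within the scatter) in this estimate. The estimated value for compound 4 is 28000 nM (expected range 12000 nM to 65000 nM).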

Compound 4, half-maximal inhibitory concentration: 35800 nM
For compound 4 the middle estimate is 1.3-fold (0.11 log units) below the measured one; measured number inside the range.
By their numbers in this assay, from the lowest: compounds 1, 3, 4 and 2 (each within the scatter of the next, the first and the last beyond it).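

In this assay, 2,5-dimethoxyphenyl in place of 3-ethoxy-4-hydroxyphenyl stays within the scatter (a 1.8-fold higher number from compound 3 to compound 4 (0.24 log units; within the scatter)), although these groups have the same atoms and only the group that leaves carries a hydrogen-bond donor. The same group also cannot be separated from 4-(dimethylamino)phenyl (a 1.5-fold lower number from compound 2 to compound 4 (0.17 log units; within the scatter)), but it does differ modestly from 4-hydroxyphenyl (a 3.0-fold higher number from compound 1 to compound 4 (0.48 log units; beyond the scatter)). Compounds 1 and 3 carry a hydroxy group, while compounds 2 and 4 do not, yet this gives no clean split into two sets: compound 3 lies within the scatter of compound 1 and of compound 4.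

Nothing available here bears on the cause of these readings. Going by these compounds, how a carboxylic acid or a primary amine on this aromatic group would read remains open.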